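The source may hold more compounds than are shown below. What is called first, only, known or untested is meant among the compounds shown, and "the series" means these compounds.

Compound 1: `Clc1ccc(-c2cc(-c3ccco3)nc(-c3cccs3)c2)o1`, 16000 nM.
Compound 2: `Clc1cccc(-c2cc(-c3ccc(Cl)o3)cc(-c3cccs3)n2)c1`, 19800 nM.

In a functional assay on K562 cells (Homo sapiens) for cytotoxicity, in the presence of a further agent that is not named here (on this read-out lower numbers stand for stronger inhibition and higher numbers for weaker inhibition), compound 1 gives 16000 nM and compound 2 gives 19800 nM. Within the data shown here, the one measured step, a 1.2-fold higher number from compound 1 to compound 2 (0.09 log units; within the scatter), leaves compound 2 and compound 1 within the scatter of each other, so compound 2 does not stand apart. Compound 3 is `Clc1ccc(-c2cc(-c3ccc(Cl)o3)cc(-c3cccs3)n2)cc1`; it differs from compound 2 in that (4-chlorophenyl in place of 3-chlorophenyl on an aromatic carbon). Among the measured compounds shown here, no measured step moves the chlorine around a chlorophenyl group, and the one step known, from furan-2-yl to 3-chlorophenyl, was small, so no step beyond the scatter is expected in this assay. Compound 3 is expected to give 20000 nM, somewhere between 8000 nM and 50000 nM. The expected step is a 1.0-fold higher number from compound 2 to compound 3 (0.00 log units; within the scatter).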

Compound 3, half-maximal inhibitory concentration: 20900 nM
Estimate against measurement, compound 3: 1.0-fold (0.02 log units) below, and the stated range covers the measured number.
By their numbers in this assay, from the lowest: compounds 1, 2 and 3 (each within the scatter of the next).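

On the aromatic carbon next to the ring nitrogen, 4-chlorophenyl in place of 3-chlorophenyl gives a result within the scatter in this assay (a 1.1-fold higher number from compound 2 to compound 3 (0.02 log units; within the scatter)), so moving the chlorine around this phenyl ring makes no readable difference here. Replacing furan-2-yl with 4-chlorophenyl at this place also stays within the scatter (a 1.3-fold higher number from compound 1 to compound 3 (0.12 log units; within the scatter)). No measurement is available that could explain this flat result. Still open, as far as these compounds go, is whether an amine, a carboxylic acid or a longer chain at this place would shift the number.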